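Alkoxy tail growth on the biaryl ether series

The source may hold more compounds than are shown below. What is called first, only, known or untested is meant among the compounds shown, and "the series" means these compounds.

For the measured compounds named here, compound 2 `CCOc1ccc(-c2cccc(COc3ccc(OCC(=O)O)c(F)c3)c2)cc1` carries the ethoxy group and stands at the highest of the two numbers measured so far: in a functional assay on CHO cells for agonist activity at Free fatty acid receptor 1 (Homo sapiens), read by FLIPR and calcium flux (on this read-out higher numbers stand for an effect only at larger amounts of compound and lower numbers for an effect already at smaller amounts), compound 2 gives 360 nM. Going by the values given here, its neighbour compound 1 `COc1ccc(-c2cccc(COc3ccc(OCC(=O)O)c(F)c3)c2)cc1` gives 170 nM in this assay, and the only measured step between them, a 2.1-fold higher number from compound 1 to compound 2 (0.33 log units; beyond the scatter), came with methyl in place of hydrogen on a saturated chain carbon bound to an oxygen on an aromatic ring. Compound 3 `O=C(O)COc1ccc(OCc2cccc(-c3ccc(OCC4CC4)cc3)c2)cc1F` continues on that same carbon: cyclopropyl in place of methyl on a saturated chain carbon bound to an oxygen on an aromatic ring, which read one bond further out is ethoxy to cyclopropylmethoxy. Among the compounds with values here, the single step that bears on this change grew the same tail and gave a modest loss. For compound 3 a step of similar size in the same direction is therefore expected, a 1.5-fold higher number from compound 2 to compound 3 (0.18 log units; within the scatter), though an outcome within the scatter cannot be ruled out. For compound 3 the expected value in this assay is 550 nM, within 200 nM to 1500 nM.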

Compound 3, half-maximal effective concentration: 540 nM
Beside the measured number, compound 3's estimate is 1.0-fold (0.01 log units) above it; the range from low to high includes it.
By their numbers in this assay, from the lowest: compound 1; then compounds 2 and 3 (each within the scatter of the next).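

In this assay, for the compounds shown here, the first change at this place to bring in a ring, cyclopropyl in place of methyl, gives a 1.5-fold higher number from compound 2 to compound 3 (0.18 log units; within the scatter), so this position takes the three-membered ring without a step that can be told apart from the scatter. Against the smallest tail shown, the same place gives a 3.2-fold higher number from compound 1 to compound 3 (0.50 log units; beyond the scatter), so the cyclopropylmethoxy tail, like the ethoxy tail, stands apart from the methoxy tail of compound 1, while the ethoxy and cyclopropylmethoxy tails cannot be ordered. Nothing on hand explains these numbers.

The compounds shown leave open whether an open chain of similar size, such as propyl or isobutyl in place of the cyclopropyl, would read like compound 3. They also leave open how a hydroxyl or an amine on this saturated chain carbon would read.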